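The source may report more compounds than this note shows. Statements on the series, on what has been measured and on what is new or still open speak of the compounds shown alone.

Measured compounds:
- compound 1, `CC(C)(C)OC(=O)/C=C1/C(=O)Nc2ccccc21`: 89.5%
- compound 2, `CN1C(=O)/C(=C/C(=O)OC(C)(C)C)c2ccccc21`: 87.5%
- compound 3, `CCCCc1ccc2c(c1)/C(=C\C(=O)OC(C)(C)C)C(=O)N2`: 89%

In a functional assay on HCT-116 cells (Homo sapiens) for inhibition, read by CCK-8 assay, with a stated time of 72 h, tested at 20 uM (a higher number here means more inhibition of growth at the concentration tested, a lower number less inhibition of growth), compound 1 gives 89.5%. Its number is the largest of the three, but that standing means little: both other numbers lie within the usual scatter of it, compound 3 nearest and compound 2 furthest. The unmeasured compound 4, `COc1ccc2c(c1)NC(=O)/C2=C/C(=O)OC(C)(C)C`, differs from compound 1 in one place: methoxy in place of hydrogen on an aromatic carbon. Among the compounds with values here, two measured steps bear on this change. The closer one is the step to compound 3, which also places a group on an aromatic carbon of the shared core and gave a number 0.5 percentage points lower from compound 1 to compound 3 (within the scatter). The step to compound 2, a change at the ring nitrogen rather than the aromatic ring, gave a number 2 percentage points lower from compound 1 to compound 2 (within the scatter). Neither change to compound 1 moved this assay beyond the scatter, so a group of a different kind on the aromatic ring is expected to behave the same way. For compound 4 the expected step from compound 1 is a number 1.5 percentage points lower from compound 1 to compound 4 (within the scatter), no movement beyond the scatter in either direction. Compound 4 is therefore estimated to give 88% in this assay, within a range from 80% to 94%.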

Compound 4, percent growth inhibition at one concentration: 89.5%
The estimate for compound 4 lay 1.5 percentage points below the measured number; the range from low to high includes it.
By their numbers in this assay, from the lowest: compounds 2, 3, 1 and 4 (each within the scatter of the next).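

In this assay, methoxy in place of hydrogen on an aromatic carbon gives no change at the digits printed from compound 1 to compound 4 (within the scatter). This shows that this aromatic carbon of the shared core can carry a group containing oxygen, with one hydrogen-bond acceptor, while the growth inhibition stays within the scatter of compound 1; compound 3 had shown this only for butyl, a chain of carbon, on a different aromatic carbon. Nothing measured here explains why the number holds when methoxy is added.

On these data alone, whether an amine, a carboxylic acid or a longer chain such as butoxy on this same aromatic carbon would also stay within the scatter remains open, as does the effect of methoxy on the other aromatic carbons of the ring. A reading at one concentration also leaves open whether compound 1 and compound 4 would separate at lower concentrations, where a full dose-response curve could show differences that a single point cannot.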